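Shortening the thioether chain on the shared core

This account rests on a few compounds, and the source may have more. Where it says the series, first, only, none or still open, it means among the compounds named here.

Compound 1 `Cc1ccc(CSc2nc3nc(C)cc(Nc4cc(-c5ccccc5)[nH]n4)n3n2)cc1` gives 7310 nM in a functional assay on PC-9 cells (Homo sapiens) for inhibition, read by MTT assay, with a stated time of 72 h; a lower number here means a stronger inhibitor, a higher number a weaker inhibitor.
Compound 2 `Cc1ccc(Cn2ccc(Nc3cc(C)nc4nc(SCc5ccc(Br)cc5)nn34)n2)cc1` gives > 50000 nM in this assay, which is a limit of the assay and not a number.

Among the compounds with values here, compound 1 thus holds the only number in this assay; the other value recorded there is the limit of > 50000 nM in this assay, at which 1 of the 2 values shown sits, so compound 1 stands alone as the one compound with a measured inhibition, and no step between compound 1 and compound 2 can be sized.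

Compound 3 `CCCSc1nc2nc(C)cc(Nc3cc(-c4ccccc4)[nH]n3)n2n1` keeps the core of compound 1 and changes only the thioether substituent: ethyl in place of 4-methylphenyl on a saturated chain carbon bound to a sulfur. The 4-methylbenzyl of compound 1 becomes propyl, with the ring gone.

Within the data shown here, with no measured step to lean on, the expectation for compound 3 rests on compound 1 alone. The step of a 2.2-fold higher number from compound 1 to compound 3 (0.34 log units; beyond the scatter) is expected to run toward weaker inhibition, beyond the usual scatter, though not by a large margin. Compound 3 is therefore estimated at 16000 nM in this assay, within a range from 5000 nM to 50000 nM.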

Compound 3, half-maximal inhibitory concentration: > 50000 nM
Compound 3 gave a limit, no number; the forecaster's own chance of this, stated with the estimate: 25%; at least 3.1-fold (0.49 log units) between middle value and limit.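

Within the data shown here, this is the first step on the shared core that can be sized: ethyl in place of 4-methylphenyl on a saturated chain carbon bound to a sulfur gives an at least 6.8-fold higher number from compound 1 to compound 3 (0.83 log units; beyond the scatter), so in this assay this place does not tolerate the loss of the ring without a change beyond the scatter. The value of compound 3, > 50000 nM, is a limit of the assay and not a number. Compound 1 therefore remains the only compound here with a measured inhibition, and the 4-methylbenzyl is the only group at this place tied to a number: the limit of > 50000 nM in this assay, at which 2 of the 3 values shown sit.

The change takes away the ring and several carbon atoms in a single step, so the compounds shown do not tell whether the aromatic ring itself or simply the size of the group accounts for the step. A cyclohexylmethyl, a plain benzyl or a longer chain such as hexyl in this place would separate these readings, and an amine or a carboxylic acid on the ring of the 4-methylbenzyl remains an open question as well.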